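From acid to amide at the assay's upper limit

The source may report more compounds than this note shows. Statements on the series, on what has been measured and on what is new or still open speak of the compounds shown alone.

Compound 1 `Nc1nccn2c1c(-c1ccc3ccc(-c4ccccc4)nc3c1F)nc2[C@H]1CC[C@H](CO)CC1` and compound 2 `Nc1nccn2c1c(-c1ccc3ccc(-c4ccccc4)nc3c1F)nc2[C@H]1CC[C@H](C(=O)O)CC1` share a core and differ in one group. In an ADME assay for permeability, using PAMPA, at pH 7.4 (on this read-out lower numbers stand for lower permeability and higher numbers for higher permeability), compound 1 gives > 1000 10^-6 cm/s, which is a limit and not a number. From the compounds shown here alone, compound 2 gives > 1000 10^-6 cm/s, which is also a limit, so its exact standing is unknown. Among the compounds with values here, the only measured step is a step that the two limits leave unreadable from compound 1 to compound 2, with carboxy in place of hydroxymethyl on a saturated ring carbon. Compound 3 `Nc1nccn2c1c(-c1ccc3ccc(-c4ccccc4)nc3c1F)nc2[C@H]1CC[C@H](C(N)=O)CC1` changes compound 2 in one place: amino in place of hydroxy on a carbonyl carbon, with amino in place of hydroxy on a carbonyl carbon. Compound 1 and compound 2 both stand at the limit of > 1000 10^-6 cm/s in this assay, at which 2 of the 2 values shown sit, so no step beyond the usual scatter is expected in this assay, and another limit is likely. The expected step is a number no higher from compound 2 to compound 3 (the limit leaves the size open). For compound 3, the estimated value is 1000 10^-6 cm/s, with an expected range from 500 10^-6 cm/s to 2000 10^-6 cm/s.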

Compound 3, apparent permeability: 63 10^-6 cm/s
Estimate against measurement, compound 3: 16-fold (1.20 log units) above; measured number below the stated range.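

Compound 3 is the only one of the three compounds shown that gives a readable number rather than a limit in this assay. Amino in place of hydroxy on the carbonyl carbon brings an at least 15-fold lower number from compound 2 to compound 3 (1.20 log units; beyond the scatter), and carbamoyl in place of hydroxymethyl on the saturated ring carbon brings an at least 15-fold lower number from compound 1 to compound 3 (1.20 log units; beyond the scatter), so exchanging a single heavy atom, with the hydrogen-bond donor count unchanged, is enough to move this read-out beyond the scatter. The earlier step from compound 1 to compound 2 could not show this, since it cannot be read with both compounds at the same limit: the limit of > 1000 10^-6 cm/s in this assay, at which 2 of the 3 values shown sit.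

From the compounds shown here alone, how far past that limit compound 1 and compound 2 truly lie remains unknown, so the full size of both steps is open. Going by these compounds, whether a methoxy or a methylamino group on this carbonyl carbon would read like amino or like hydroxy is also open.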